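The source may hold more compounds than are shown below. What is called first, only, known or untested is meant among the compounds shown, and "the series" means these compounds.

Measured in a functional assay on SiHa cells (Homo sapiens) for antiproliferative activity, read by CCK-8 assay, with a stated time of 72 h; a lower number here means a stronger inhibitor, a higher number a weaker inhibitor:
- Compound 1 `COc1ccc(-c2cncnc2-c2cc(OC)c(OC)c(OC)c2)cc1O`: 2750 nM
- Compound 2 `COc1ccc(-c2cncnc2-c2cc(OC)c(OC)c(OC)c2)cc1F`: 3340 nM

Compound 2 gives 3340 nM and compound 1 gives 2750 nM. These values lie within the scatter of each other, so neither compound can be ranked ahead of the other.

Compound 3 `COc1cc(-c2ncncc2-c2ccc(SC)cc2)cc(OC)c1OC` differs from compound 2 in a single group: 4-(methylsulfanyl)phenyl in place of 3-fluoro-4-methoxyphenyl on an aromatic carbon. Here 4-(methylsulfanyl)phenyl takes the place of 3-fluoro-4-methoxyphenyl, on the same aromatic carbon, ortho to a large group.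

For the measured compounds named here, only one measured step bears on this change: a 1.2-fold higher number from compound 1 to compound 2 (0.08 log units; within the scatter). Exchanging hydroxy for fluoro on the group now being replaced therefore left the number within the scatter. This is thin evidence, since that step altered one substituent, whereas this change replaces the whole group and brings in sulfur, which neither measured compound carries.

In this assay, no shift beyond the scatter is expected, but the uncertainty is wide in both directions. The expected change is a 1.1-fold lower number from compound 2 to compound 3 (0.05 log units; within the scatter). Compound 3 is estimated at 3000 nM, with an expected range from 700 nM to 12000 nM.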

Compound 3, half-maximal inhibitory concentration: 560 nM
Compound 3: middle estimate off by 5.4-fold (0.73 log units), on the high side, and the stated range ends above it.
By their numbers in this assay, from the lowest: compound 3; then compounds 1 and 2 (each within the scatter of the next).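

Replacing the whole group at this position has an effect that the earlier exchange of hydroxy for fluoro did not show: this assay gives a 6.0-fold lower number from compound 2 to compound 3 (0.78 log units; beyond the scatter), and starting from the hydroxy compound it gives a 4.9-fold lower number from compound 1 to compound 3 (0.69 log units; beyond the scatter). The position is therefore sensitive to what it carries, even though the groups compared in the step from compound 2 each hold one six-membered aromatic ring of carbon only and have the same counts of hydrogen-bond donors and acceptors. No measurement shown here explains the lower number, so its cause remains unknown.

This single change removes the 3-fluoro and 4-methoxy substituents and brings in 4-(methylsulfanyl), so the compounds shown leave open which of these differences matters, and a plain 4-methoxyphenyl group would help separate them. Also open, from the compounds shown here alone, is how the number would respond to a longer chain on the sulfur, as in 4-(ethylsulfanyl)phenyl, or to an amine at the same ring position, as in 4-aminophenyl.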